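Lipophilicity notes: aryl variation on the isoxazoline spiro-lactone series

The source may report more compounds than this note shows. Statements on the series, on what has been measured and on what is new or still open speak of the compounds shown alone.

Measured so far in a physicochemical assay for lipophilicity; a lower number here means a more polar compound, a higher number a more lipophilic compound:
- compound 1 `C[C@H]1CC[C@@H]2[C@@H](OC(=O)[C@]23CC(c2ccc(N(C)C)cc2)=NO3)[C@]2(C)C(=O)C=C[C@@]12O` gives 1.51
- compound 2 `C[C@H]1CC[C@@H]2[C@@H](OC(=O)[C@]23CC(c2ccccc2[N+](=O)[O-])=NO3)[C@]2(C)C(=O)C=C[C@@]12O` gives 1.37
- compound 3 `C[C@H]1CC[C@@H]2[C@@H](OC(=O)[C@]23CC(c2cccc([N+](=O)[O-])c2)=NO3)[C@]2(C)C(=O)C=C[C@@]12O` gives 1.37

Compound 2 stands level with compound 3 at the digits shown (no change at the digits printed from compound 2 to compound 3 (within the scatter)). The remaining two steps in the set are within the scatter as well: a number 0.14 log units lower from compound 1 to compound 2 (within the scatter), and likewise a number 0.14 log units lower from compound 1 to compound 3 (within the scatter). All three numbers therefore lie within the scatter of one another; nothing in this set separates the three aryl groups on the carbon with a double bond to nitrogen.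

Compound 4 `Cc1ccc(C2=NO[C@]3(C2)C(=O)O[C@@H]2[C@H]3CC[C@H](C)[C@]3(O)C=CC(=O)[C@@]23C)cc1` is not yet measured. Relative to compound 2 the change is 4-methylphenyl in place of 2-nitrophenyl on a carbon with a double bond to nitrogen.

No measured step exchanges a nitro-bearing ring for a methyl-bearing one, so the measured steps bear on this only loosely: the exchange of 4-(dimethylamino)phenyl for either nitrophenyl moved the number within the scatter, and the position of the nitro group made no difference at the digits shown. The change to compound 4 removes both acceptors counted above and adds only carbon, so a rise beyond the scatter is expected, though the small measured steps argue against a large one. For compound 4 the expected value in this assay is 1.85, with a range of 1.5 to 2.3, which is an expected step of a number 0.48 log units higher from compound 2 to compound 4 (beyond the scatter).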

Compound 4, partition coefficient: 1.86
Compound 4: the middle estimate sits 0.01 log units below what was measured; low and high end bracket the measured number.
By their numbers in this assay, from the lowest: compounds 2, 3 and 1 (each within the scatter of the next); then compound 4.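

In this assay, the aryl group on the carbon with a double bond to nitrogen does separate compounds once 4-methylphenyl enters: the exchange for 2-nitrophenyl gives a number 0.49 log units higher from compound 2 to compound 4 (beyond the scatter), and the exchange for 3-nitrophenyl gives a number 0.49 log units higher from compound 3 to compound 4 (beyond the scatter). Methyl in place of dimethylamino on an aromatic carbon gives a number 0.35 log units higher from compound 1 to compound 4 (beyond the scatter), so compound 4 stands apart from all three earlier compounds, which remain within the scatter of one another. No measurement at hand bears on what lies behind these steps.

From the compounds shown here alone, with a single methyl-bearing ring in the set, these steps do not show whether the separation follows from having methyl on the ring or from losing the nitro and dimethylamino groups, and the effect of moving the methyl to another ring carbon also stays open. Going by these compounds, it also remains open where the unsubstituted phenyl, a longer chain such as 4-ethylphenyl, or a ring bearing a carboxylic acid would fall relative to compound 4 and the three lower compounds.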